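Dropping one fluoro from a hydroxamic acid: metabolic stability

The compounds below may be only part of what the source reports. "The series", "measured", "known", "first", "only" and "open" are said of these compounds alone.

Compound 1 `CCC(C)(C)C(=O)N(O)Cc1ccc(F)c(F)c1F`: 0.882 h
Compound 2 `CCC(C)(C)C(=O)NCc1ccccc1`: > 3.33 h
Compound 3 `CCC(C)(C)C(=O)NC(CO)c1ccccc1`: > 3.33 h

Going by the values given here, in an ADME assay on microsomes from liver (Homo sapiens) for metabolic stability, read by LC-MS, using NADPH (on this read-out higher numbers stand for a longer-lived compound and lower numbers for a shorter-lived compound), compound 1 gives 0.882 h, the only plain number among the three results. The value of compound 2 is a limit of the assay. The value of compound 3 is likewise a limit. The step that the two limits leave unreadable from compound 2 to compound 3 therefore cannot be read, and the limit of > 3.33 h in this assay, at which 2 of the 3 values shown sit, is all that these two results show.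

Compound 4 `CCC(C)(C)C(=O)N(O)Cc1ccc(F)c(F)c1` differs from compound 1 by hydrogen in place of fluoro on an aromatic carbon. Among the compounds with values here, no measured step touches a fluoro group, so nothing among the results shows which way this change moves the half-life. The expectation is a step of about a 1.0-fold higher number from compound 1 to compound 4 (0.01 log units; within the scatter), within the scatter. Compound 4 is estimated at 0.9 h, between 0.4 h and 2 h.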

Compound 4, half-life: 1.78 h
For compound 4 the middle estimate is 2.0-fold (0.30 log units) below the measured one, and the stated range covers the measured number.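

The earlier compounds shown here held no step on a fluoro group. In this assay, hydrogen in place of fluoro, on an aromatic carbon ortho to a fluoro group and ortho to a large group, gives a 2.0-fold higher number from compound 1 to compound 4 (0.30 log units; within the scatter). This fluoro can therefore go without the half-life leaving the usual scatter of repeated measurements, and nothing shown here explains the step.

Going by these compounds, whether a chloro or a methoxy group at this same place would behave alike stays open. So does what happens when either remaining fluoro group is replaced by hydrogen.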